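Notes on the sulfonyl aryl change from compound 3 to compound 4

The source may hold more compounds than are shown below. What is called first, only, known or untested is meant among the compounds shown, and "the series" means these compounds.

Measured so far in an assay on MDA-MB-231 cells for displacement of a labelled ligand from C-X-C chemokine receptor type 4 (Homo sapiens), read by fluorescence and microscopy, with stated times of 10 min and 30 min; on this read-out higher numbers stand for an effect only at larger amounts of compound and lower numbers for an effect already at smaller amounts:
compound 1 `Cc1ccccc1C(=O)NCc1ccc(CNS(=O)(=O)c2ccccc2C)cc1` gives 10 nM
compound 2 `O=C(NCc1ccc(CNS(=O)(=O)c2cccc(F)c2)cc1)c1cccnc1` gives 1000 nM
compound 3 `O=C(NCc1ccc(CNS(=O)(=O)c2cccc(Cl)c2)cc1)c1cccnc1` gives 100 nM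

Compound 3 stands second highest of the three numbers: compound 1 sits lower and compound 2 higher, both gaps beyond the scatter.

For the measured compounds named here, compound 4 `Cc1ccccc1S(=O)(=O)NCc1ccc(CNC(=O)c2cccnc2)cc1` is not yet measured. 2-methylphenyl in place of 3-chlorophenyl on a sulfonyl sulfur The only measured step that changes a single place is a 10-fold lower number from compound 2 to compound 3 (1.00 log units; beyond the scatter). It concerns the same sulfonyl position but a different pair of groups, so it bears on the present change only loosely, showing that the aryl on the sulfonyl sulfur can move the number by a modest amount. Going by the values given here, compound 1 carries the same 2-methylphenyl on its sulfonyl sulfur as compound 4, but its amide part also differs from that of compound 3, so no single step connects them. Compound 1 gives 10 nM. Compound 3 gives 100 nM. Those two values are all that pair shows.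

For compound 4 a downward step is expected, a 3.3-fold lower number from compound 3 to compound 4 (0.52 log units; beyond the scatter), modest rather than large. Compound 4 is therefore estimated at 30 nM, within the range 8 nM to 100 nM.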

Compound 4, effective concentration (reported as EC, without a stated level of effect): 1000 nM
Beside the measured number, compound 4's estimate is 33-fold (1.52 log units) below it, outside the stated range (above it).
By their numbers in this assay, from the lowest: compound 1; then compound 3; then compounds 2 and 4 (each within the scatter of the next).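

With the pyridin-3-yl amide held fixed in this assay, 2-methylphenyl on the sulfonyl sulfur does not keep what 3-chlorophenyl gives (a 10-fold higher number from compound 3 to compound 4 (1.00 log units; beyond the scatter)), and it stands level with 3-fluorophenyl (no change at the digits printed from compound 2 to compound 4 (within the scatter)), so among these three groups only 3-chlorophenyl sets itself apart on this amide. The low number seen earlier therefore does not follow from the 2-methylphenyl on the sulfonyl sulfur alone: with that group kept, pyridin-3-yl in place of 2-methylphenyl on a carbonyl carbon makes the largest single step of the set (a 100-fold higher number from compound 1 to compound 4 (2.00 log units; beyond the scatter)). Nothing measured here gives a reason for either step.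

The compounds shown leave open whether 3-chlorophenyl on the sulfonyl sulfur would also lower the number when 2-methylphenyl sits on the carbonyl carbon, and so whether the two places act independently of each other. They also leave open how other groups on the sulfonyl sulfur would read, such as 3-methylphenyl, 3-bromophenyl or a plain methyl, and how an amine-bearing group would read on the carbonyl carbon.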